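The source may hold more compounds than are shown below. What is called first, only, known or untested is meant among the compounds shown, and "the series" means these compounds.

Measured compounds:
- compound 1 `CC1=CC[C@H]2[C@H](CC[C@]2(C)O)C(C)(C)[C@@H]1CC[C@H]1[C@]2(C)CC[C@H](OC(=O)c3ccc(Cl)cc3)C(C)(C)O[C@H]2CC[C@@]1(C)O`: 24100 nM
- compound 2 `CC1=CC[C@H]2[C@@H]1CC=C(C)[C@@H](CC[C@H]1[C@]3(C)CC[C@H](OC(=O)c4ccncc4)C(C)(C)O[C@H]3CC[C@@]1(C)O)C2(C)C`: a limit, > 50000 nM
- compound 3 `CC1=CC[C@H]2[C@@H]1CC=C(C)[C@@H](CC[C@H]1[C@]3(C)CC[C@H](OC(=O)c4ccc(Cl)cc4)C(C)(C)O[C@H]3CC[C@@]1(C)O)C2(C)C`: 22000 nM

In a functional assay on MCF7 cells (Homo sapiens) for antiproliferative activity, read by MTT assay, with a stated time of 72 h (a lower number here means a stronger inhibitor, a higher number a weaker inhibitor), compound 1 gives 24100 nM. Compound 3 gives 22000 nM in this assay, and the two numbers lie within the scatter of each other, so neither can be called the stronger. Compound 2 gives only a limit in this assay, > 50000 nM; (the limit of > 50000 nM in this assay, at which 1 of the 3 values shown sits).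

Compound 4 `CC1=CC[C@H]2[C@H](CC[C@]2(C)O)C(C)(C)[C@@H]1CC[C@H]1[C@]2(C)CC[C@H](OC(=O)c3ccccc3F)C(C)(C)O[C@H]2CC[C@@]1(C)O` differs from compound 1 in one place: 2-fluorophenyl in place of 4-chlorophenyl on a carbonyl carbon. Among the measured compounds shown here, the one measured step that touches this part of the molecule is an at least 2.2-fold lower number from compound 2 to compound 3 (0.35 log units; beyond the scatter), which shows that the aromatic ring on the carbonyl can shift the number at least modestly. For the measured compounds named here, no measured step swaps one halogenated phenyl for another, so direction and size here are uncertain; a change within or just beyond the scatter seems most likely. Compound 4 is therefore expected to give about 30000 nM, between 12000 nM and 80000 nM, which means an expected 1.2-fold higher number from compound 1 to compound 4 (0.10 log units; within the scatter).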

Compound 4, half-maximal inhibitory concentration: 11300 nM
Compound 4: middle estimate off by 2.7-fold (0.42 log units), on the high side; the whole stated range lies above it.
By their numbers in this assay, from the lowest: compounds 4, 3 and 1 (each within the scatter of the next, the first and the last beyond it). At a limit, above all of these: compound 2.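

In this assay, the earlier step showed only that a 4-chlorophenyl and a pyridin-4-yl on this carbonyl carbon give different results. The new step shows that the number can also move when one halogenated phenyl replaces another, with a 2.1-fold lower number from compound 1 to compound 4 (0.33 log units; beyond the scatter) on the same core. The exchange keeps the heavy-atom count of the group the same, so a different halogen at a different place on the phenyl ring is enough for this modest shift. Nothing measured here explains why this exchange lowers the number.

From the compounds shown here alone, the change of halogen and the change of its place on the ring are made together, so their separate contributions remain unknown. A 4-fluorophenyl or a 2-chlorophenyl on this carbonyl would separate them, and a 2-aminophenyl would test a group without a halogen.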